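The compounds below may be only part of what the source reports. "The series", "measured", "known", "first", "only" and "open" are said of these compounds alone.

Measured in a functional assay on A549 cells (Homo sapiens) for inhibition, read by sulforhodamine B assay, with a stated time of 72 h; a lower number here means a stronger inhibitor of growth, a higher number a weaker inhibitor of growth:
Compound 1 `CN1CCN(C(=O)/C=C/c2ccncc2-c2ccc3ccccc3c2)CC1`: > 10000 nM
Compound 2 `CCOC(=O)/C=C/c1ccncc1-c1ccc2ccccc2c1`: 5380 nM
Compound 3 `O=C(O)/C=C/c1ccncc1-c1ccc2ccccc2c1`: > 10000 nM

Compound 3 gives > 10000 nM, which is a limit and not a number. Compound 1 gives > 10000 nM, also a limit. Together they make up (the limit of > 10000 nM in this assay, at which 2 of the 3 values shown sit).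

Compound 4 `COC1CN(C(=O)/C=C/c2ccncc2-c2ccc3ccccc3c2)C1` carries 3-methoxyazetidin-1-yl in place of hydroxy on a carbonyl carbon. Compound 1 differs from compound 3 at the same carbonyl carbon, and that step is a step that the two limits leave unreadable from compound 1 to compound 3. The other measured steps are an at least 1.8-fold lower number from compound 1 to compound 2 (0.26 log units; that floor lies within the scatter) and an at least 1.8-fold higher number from compound 2 to compound 3 (0.26 log units; that floor lies within the scatter). In this assay, no change beyond the scatter is therefore expected, and the estimated step is an at least 1.1-fold lower number from compound 3 to compound 4 (0.04 log units; that floor lies within the scatter). For compound 4 the estimate is 9000 nM, with an expected range of 3500 nM to 20000 nM.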

Compound 4, concentration for 50% growth inhibition: > 10000 nM
Compound 4: no number, only a limit; the forecaster's own chance of this, stated with the estimate: 55%; at least 1.1-fold (0.04 log units) between middle value and limit.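

With 3-methoxyazetidin-1-yl, a third group on this carbonyl carbon reaches the limit in this assay: the limit of > 10000 nM in this assay, at which 3 of the 4 values shown sit.

The one readable step is an at least 1.8-fold higher number from compound 2 to compound 4 (0.26 log units; that floor lies within the scatter), so ethoxy remains the only group shown that gives a number, though that floor does not set it apart. The steps among compounds 1, 3 and 4 cannot be read, since all three values are limits.

The compounds shown leave open how far past the limit those three lie. They also leave open whether methoxy or propoxy on the same carbonyl carbon would give a number.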